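Swapping the fluorophenyl of compound 2 for an ethylphenyl

The compounds below may be only part of what the source reports. "The series", "measured", "known", "first", "only" and "open" are said of these compounds alone.

Three compounds sharing one core have been measured in a functional assay (muscle tissue) with Cavia porcellus as the target; on this read-out lower numbers stand for an effect already at smaller amounts and higher numbers for an effect only at larger amounts of compound:

compound 1, `COC(=O)C1=C(C)N=C(C)/C(=C(\O)OC)C1c1c(F)c(F)c(F)c(F)c1F`, gives 4.37 nM
compound 2, `COC(=O)C1=C(C)N=C(C)/C(=C(\O)OC)C1c1ccc(F)cc1`, gives 129 nM
compound 3, `COC(=O)C1=C(C)N=C(C)/C(=C(\O)OC)C1c1cccc(N(C)C)c1`, gives 891 nM

Among these three numbers compound 2 stands second highest. Its nearest neighbour is compound 3, whose number is higher by an amount beyond the scatter; the furthest is compound 1, whose number is lower by a still larger amount, also beyond the scatter. Compound 4, `CCc1ccccc1C1C(C(=O)OC)=C(C)N=C(C)/C1=C(\O)OC`, has not yet been measured. It differs from compound 2 in one place: 2-ethylphenyl in place of 4-fluorophenyl on a saturated ring carbon. Among the compounds with values here, no step between two measured compounds matches this change, so the expectation can rest only on how widely the three measured compounds, which differ in the group on the saturated ring carbon, are spread in this assay. For compound 4 a downward step beyond the scatter is expected, a 2.2-fold lower number from compound 2 to compound 4 (0.33 log units; beyond the scatter), though the direction is uncertain. The estimated value for compound 4 is 60 nM, with a range from 12 nM to 300 nM.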

Compound 4, half-maximal effective concentration: 6.46 nM
For compound 4 the middle estimate is 9.3-fold (0.97 log units) above the measured one; the whole stated range lies above it.
By their numbers in this assay, from the lowest: compounds 1 and 4 (each within the scatter of the next); then compound 2; then compound 3.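

In this assay, the move to 2-ethylphenyl on the saturated ring carbon gives a 20-fold lower number from compound 2 to compound 4 (1.30 log units; beyond the scatter), showing that a group without fluorine can sit at this position and still give a number as low as that of the polyfluorinated compound 1 at 4.37 nM, with compound 4 at 6.46 nM, the two lying within the scatter of each other. Fluorine on the aromatic ring is therefore not what separates low numbers from higher ones among these compounds, and compound 2, which carries fluorine yet has a much higher number, goes against any such link. Nothing shown here offers a reason for this large step.

From the compounds shown here alone, whether the step belongs to the ethyl group itself or to where it stands on the aromatic ring stays open, since 2-ethylphenyl and 4-fluorophenyl differ in both. Also unknown is whether a longer chain, an amine or a carboxylic acid in place of the ethyl group would keep the number this low.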